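Working notes: piperazin-1-yl to 4-propylpiperazin-1-yl

This account rests on a few compounds, and the source may have more. Where it says the series, first, only, none or still open, it means among the compounds named here.

Values in a functional assay on A549 cells (Homo sapiens) for cytotoxicity, read by MTT assay, with a stated time of 72 h; a higher number here means a weaker inhibitor, a lower number a stronger inhibitor:
- compound 1 `O=C1c2c[n+]([O-])c3ccccc3c2C(=O)c2c1c1ccccc1n2Cc1cn(C[C@H](O)CO)nn1`: 1030 nM
- compound 2 `O=C1c2c[n+]([O-])c3ccccc3c2C(=O)c2c1c1ccccc1n2CCN1CCCC1`: 410 nM
- compound 3 `O=C1c2c[n+]([O-])c3ccccc3c2C(=O)c2c1c1ccccc1n2CCCCN1CCNCC1`: 540 nM

Compound 3, at 540 nM, lies within the scatter of both other compounds. The next structure, compound 4 `CCCN1CCN(CCCCn2c3c(c4ccccc42)C(=O)c2c[n+]([O-])c4ccccc4c2C3=O)CC1`, is still unmeasured. Its difference is propyl in place of hydrogen on an amine nitrogen in a ring. Among the compounds with values here, no measured step tests any group on that nitrogen, so the evidence is indirect. The closest steps are exchanges of the group on the chain: a 1.3-fold higher number from compound 2 to compound 3 (0.12 log units; within the scatter) and a 1.9-fold lower number from compound 1 to compound 3 (0.28 log units; within the scatter), both within the scatter. The largest is a 2.5-fold lower number from compound 1 to compound 2 (0.40 log units; beyond the scatter), which is only modest. On that basis, no step beyond the scatter is expected in this assay, and no direction can be firmly assigned. The estimated step is a 1.2-fold lower number from compound 3 to compound 4 (0.08 log units; within the scatter). The expected value for compound 4 is 450 nM, with an estimated range of 180 nM to 1100 nM.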

Compound 4, half-maximal inhibitory concentration: 320 nM
Compound 4: the middle estimate sits 1.4-fold (0.15 log units) above what was measured; measured number inside the range.
By their numbers in this assay, from the lowest: compounds 4, 2, 3 and 1 (each within the scatter of the next, the first and the last beyond it).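

In this assay, within the data shown here, the step of a 1.7-fold lower number from compound 3 to compound 4 (0.23 log units; within the scatter) is the first direct reading of a group on the amine nitrogen in the ring, and it shows that propyl in place of hydrogen is tolerated there, with no change beyond the scatter. The step of a 1.3-fold lower number from compound 2 to compound 4 (0.11 log units; within the scatter) leaves 2-(4-propylpiperazin-1-yl)ethyl indistinguishable from pyrrolidin-1-yl on the chain, while a 3.2-fold lower number from compound 1 to compound 4 (0.51 log units; beyond the scatter) is a second step beyond the scatter away from compound 1, joining a 2.5-fold lower number from compound 1 to compound 2 (0.40 log units; beyond the scatter). The data shown include no measurement that bears on the reason for these numbers.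

Still open, as far as these compounds go, is whether a longer chain than propyl, a benzyl group or an acetyl group on that nitrogen would stay within the scatter of compound 3. A carboxylic acid at the end of a propyl chain there is equally untested by the compounds shown.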